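Inverting One Chain Stereocentre in Compound 1

A few compounds are considered here, and "the series" means these few. Any claim that something is new, unique, unknown or untested is made for them only; others in the source may bear on it.

Measured in a functional assay on HL-60 cells (Homo sapiens) for cytotoxicity, read by WST assay, with a stated time of 48 h; a higher number here means a weaker inhibitor, a lower number a stronger inhibitor:
- compound 1 `COC[C@H](C)[C@H](C)C(c1ccc(O)c(OC)c1)c1ccc(O)c(OC)c1`: 82000 nM
- compound 2 `COc1cc(C(c2ccc(O)c(OC)c2)[C@H](C)[C@H](C)CO)ccc1O`: > 100000 nM (a limit of the assay)
- compound 3 `COc1cc(C(c2ccc(O)c(OC)c2)[C@@H](C)C(C)C)ccc1O`: 20000 nM

Compound 1 holds the higher of the two actual numbers, and the step of a 4.1-fold lower number from compound 1 to compound 3 (0.61 log units; beyond the scatter) separates it from the other. Compound 4 `COC[C@H](C)[C@@H](C)C(c1ccc(O)c(OC)c1)c1ccc(O)c(OC)c1` is the next to be tested in this assay. Its relation to compound 1 is the two compounds have the same atoms and bonds and differ only in configuration as drawn: 1 of 2 stereo elements differ; a stereocentre at a saturated chain carbon is drawn R in compound 1 and S in compound 4. The steps of an at least 1.2-fold higher number from compound 1 to compound 2 (0.08 log units; that floor lies within the scatter) and a 4.1-fold lower number from compound 1 to compound 3 (0.61 log units; beyond the scatter) both exchange groups on the chain, so neither measures a change of configuration alone. No shift beyond the scatter is therefore expected, in either direction. The estimated step is a 1.2-fold lower number from compound 1 to compound 4 (0.07 log units; within the scatter). The estimate for compound 4 is 70000 nM, with an expected range of 30000 nM to 130000 nM.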

Compound 4, half-maximal inhibitory concentration: 68000 nM
Compound 4: the middle estimate sits 1.0-fold (0.01 log units) above what was measured; measured number inside the range.
By their numbers in this assay, from the lowest: compound 3; then compounds 4 and 1 (each within the scatter of the next). At a limit, above all of these: compound 2.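

In this assay, among these compounds, inverting this one stereocentre gives a 1.2-fold lower number from compound 1 to compound 4 (0.08 log units; within the scatter), the only step here that isolates configuration: the fact that compounds 1 and 4 differ only in the configuration as drawn. The group exchange on the chain still registers with the stereocentre drawn S, as a 3.4-fold higher number from compound 3 to compound 4 (0.53 log units; beyond the scatter) shows for 2-(methoxymethyl)-1-methylpropyl in place of 1,2-dimethylpropyl. Compound 2 stands at a limit, so an at least 1.4-fold lower number from compound 2 to compound 4 (0.16 log units; that floor lies within the scatter) gives only a floor.

The compounds shown leave open whether inverting the other stereocentre alone would behave the same way. They also leave open whether this inversion would stay within the scatter with an amine or a carboxylic acid in place of the methoxy group.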